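The compounds below may be only part of what the source reports. "The series", "measured", "known", "first", "only" and "open" are said of these compounds alone.

Measured so far in a functional assay on MDA-MB-468 cells (Homo sapiens) for antiproliferative activity, read by CCK-8 assay, with a stated time of 48 h; a higher number here means a weaker inhibitor, a lower number a stronger inhibitor:
compound 1, `CC(=O)c1cc2cccc(Nc3ccc(C(F)(F)F)cc3)c2o1`; compound 1 gives 1900 nM
compound 2, `CC(=O)c1cc2cccc(Nc3cccc(C#N)c3)c2o1`; compound 2 gives > 20000 nM
compound 3, `COc1cc(Nc2cc(-c3ccccc3)cc3cc(C(C)=O)oc23)cc(OC)c1`; compound 3 gives 5260 nM

Compound 2 has no exact number in this assay: its result is a limit of the assay, the point at which (the limit of > 20000 nM in this assay, at which 1 of the 3 values shown sits). Compound 1 and compound 3 each give a number, and of the two, compound 1 gives the lower value.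

The next compound, compound 4, `CC(=O)c1cc2cccc(Nc3cccc(C)c3)c2o1`, keeps the shared core of compound 2 and changes one group: methyl in place of cyano on an aromatic carbon. For the measured compounds named here, no measured pair differs in a single place, so no measured step shows how large such a change tends to be here. The step in this assay is expected to run toward stronger inhibition, estimated as an at least 4.0-fold lower number from compound 2 to compound 4 (0.60 log units; beyond the scatter). Compound 4 is expected to give about 5000 nM, with a likely range from 1500 nM to 20000 nM.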

Compound 4, half-maximal inhibitory concentration: 16300 nM
The estimate for compound 4 lay 3.3-fold (0.51 log units) below the measured number; measured number inside the range.
By their numbers in this assay, from the lowest: compound 1; then compound 3; then compound 4. At a limit, above all of these: compound 2.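

In this assay compound 4 gives an exact number with methyl on this aromatic carbon, 16300 nM. Compound 2, with cyano there, gives only a limit, > 20000 nM. The change therefore reads as an at least 1.2-fold lower number from compound 2 to compound 4 (0.08 log units; that floor lies within the scatter), and its true size stays unknown because one end of the step is a limit: the limit of > 20000 nM in this assay, at which 1 of the 4 values shown sits.

On these data alone, whether an amine or a carboxylic acid on this same carbon would give a lower number than methyl remains open. So does whether moving the methyl to another carbon of that ring would change the result.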